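Adding one methoxy to compound 2: working notes

The source may hold more compounds than are shown below. What is called first, only, known or untested is meant among the compounds shown, and "the series" means these compounds.

- compound 1 `COc1cc(C(=O)NNC(=O)c2ccc3[nH]c(-c4ccc([N+](=O)[O-])s4)nc3c2)cc(OC)c1OC` gives 62.5 ug/mL
- compound 2 `COc1ccc(C(=O)NNC(=O)c2ccc3[nH]c(-c4ccc([N+](=O)[O-])o4)nc3c2)cc1OC` gives 15.6 ug/mL

In a functional assay on NCI-H460 cells (Homo sapiens) for inhibition, read by sulforhodamine B assay, with a stated time of 48 h (on this read-out higher numbers stand for weaker inhibition of growth and lower numbers for stronger inhibition of growth), compound 2 at 15.6 ug/mL holds the lower of the two numbers, and the gap to compound 1 lies beyond the scatter. Compound 3 `COc1cc(C(=O)NNC(=O)c2ccc3[nH]c(-c4ccc([N+](=O)[O-])o4)nc3c2)cc(OC)c1OC` follows from compound 2 by methoxy in place of hydrogen on an aromatic carbon with methoxy in place of hydrogen on an aromatic carbon. Going by the values given here, no measured pair isolates this change. Compound 1 shares the methoxy groups of compound 3 but also differs from it elsewhere, so compound 1 at 62.5 ug/mL is only a loose guide. The expected step of a 1.8-fold higher number from compound 2 to compound 3 (0.25 log units; within the scatter) is a small rise in this assay toward weaker inhibition of growth, within the scatter. Compound 3 is estimated at 28 ug/mL with an expected range from 10 ug/mL to 70 ug/mL for the coming measurement.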

Compound 3, concentration for 50% growth inhibition: 31.3 ug/mL
Estimate against measurement, compound 3: 1.1-fold (0.05 log units) below; measured number inside the range.
By their numbers in this assay, from the lowest: compounds 2, 3 and 1 (each within the scatter of the next, the first and the last beyond it).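

In this assay, the added methoxy on the aromatic carbon gives a 2.0-fold higher number from compound 2 to compound 3 (0.30 log units; within the scatter), so this position tolerates the third methoxy group within the scatter. With the three methoxy groups held constant, 5-nitrofuran-2-yl in place of 5-nitrothiophen-2-yl gives a 2.0-fold lower number from compound 1 to compound 3 (0.30 log units; within the scatter), again within the scatter. No measurement available here bears on the reason for either step.

On these data alone, whether a hydroxyl, an amine or a longer chain such as ethoxy on this aromatic carbon would move the number beyond the scatter remains open. Going by these compounds alone, also open is whether the 5-nitrofuran-2-yl and 5-nitrothiophen-2-yl groups stay within the scatter of each other when the ring carries only two methoxy groups.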